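The source may hold more compounds than are shown below. What is called first, only, known or untested is meant among the compounds shown, and "the series" means these compounds.

Among the compounds with values here, compound 2 `CC1=C(C(C)C(=O)NCCN2CCCCC2)c2cc(F)ccc2/C1=C\c1ccc([S+](C)[O-])cc1` gives 36300 nM in a functional assay on PC-3 cells (Homo sapiens) for inhibition, read by CellTiter-Glo, with a stated time of 72 h; a higher number here means that more compound is tolerated, a lower number that less compound is tolerated; it holds the lowest of the two numbers so far, and its only neighbour is compound 1 `CC1=C(C(C)C(=O)N(C)CCN(C)C)c2cc(F)ccc2/C1=C\c1ccc([S+](C)[O-])cc1`, which gives 44600 nM in this assay. Within the data shown here, the one step measured, a 1.2-fold lower number from compound 1 to compound 2 (0.09 log units; within the scatter), sits at the carbonyl carbon and stays within the scatter. Compound 3 `CC1=C(C(C)C(=O)N2CCN(c3ccncc3)CC2)c2cc(F)ccc2/C1=C\c1ccc([S+](C)[O-])cc1` differs from compound 2 by 4-(pyridin-4-yl)piperazin-1-yl in place of (2-(piperidin-1-yl)ethyl)amino on a carbonyl carbon. That lone step gives no direction for the present change, so no step beyond the scatter is expected; compound 3 is estimated at 40000 nM (range 15000 nM to 100000 nM) in this assay, a step of a 1.1-fold higher number from compound 2 to compound 3 (0.04 log units; within the scatter) from compound 2 to compound 3.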

Compound 3, half-maximal cytotoxic concentration: 10500 nM
Compound 3: middle estimate off by 3.8-fold (0.58 log units), on the high side, outside the stated range (below it).
By their numbers in this assay, from the lowest: compound 3; then compounds 2 and 1 (each within the scatter of the next).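

At the carbonyl carbon, the group carried on the amide can shift the number in this assay: 4-(pyridin-4-yl)piperazin-1-yl gives a 3.5-fold lower number from compound 2 to compound 3 (0.54 log units; beyond the scatter) and a 4.2-fold lower number from compound 1 to compound 3 (0.63 log units; beyond the scatter), whereas the two open-chain amines stayed within the scatter of each other. The step is modest, and no measurement on hand accounts for it.

The compounds shown leave open whether the step follows the piperazine ring or the pyridin-4-yl ring, as both enter together. A 4-methylpiperazin-1-yl or 4-phenylpiperazin-1-yl group on the same carbonyl carbon would separate the two.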